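Swapping an amide for a sulfonamide on the piperidine ring

The source may hold more compounds than are shown below. What is called first, only, known or untested is meant among the compounds shown, and "the series" means these compounds.

Compound 1 `Cn1cncc1CN1CC(N(CC2CCN(C(=O)c3ccc(Cl)cc3)CC2)S(=O)(=O)c2ccccn2)Cc2cc(C#N)ccc21` gives 0.5 10^-6 cm/s in an ADME assay on Caco-2 cells (Homo sapiens) for permeability, in the apical to basolateral direction (a higher number here means that the compound crosses the layer faster, a lower number that the compound crosses the layer more slowly), and compound 2 `C=C(C)C(=O)N1CCC(CN(C2Cc3cc(C#N)ccc3N(Cc3cncn3C)C2)S(=O)(=O)c2ccccn2)CC1` gives 0.5 10^-6 cm/s, so the two stand level. Among the measured compounds shown here, the only step in hand, no change at the digits printed from compound 1 to compound 2 (within the scatter), changed a group on the same carbonyl carbon without moving the number. Compound 3 `Cn1cnc(S(=O)(=O)N2CCC(CN(C3Cc4cc(C#N)ccc4N(Cc4cncn4C)C3)S(=O)(=O)c3ccccn3)CC2)c1` differs from compound 1 as follows: (1-methyl-1H-imidazol-4-yl)sulfonyl in place of (4-chlorophenyl)carbonyl on an amine nitrogen in a ring. That step is not covered by any measured pair, so the expected step of a 1.7-fold lower number from compound 1 to compound 3 (0.22 log units; within the scatter) is a cautious guess. Compound 3 is estimated at 0.3 10^-6 cm/s, within a range from 0.1 10^-6 cm/s to 1 10^-6 cm/s.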

Compound 3, apparent permeability: 0.1 10^-6 cm/s
The estimate for compound 3 lay 3.0-fold (0.48 log units) above the measured number, within the range that was stated.
By their numbers in this assay, from the lowest: compound 3; then compounds 1 and 2 (each within the scatter of the next).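

On this amine nitrogen in a ring, this assay did not separate the two carbonyl groups, but the position is not indifferent to every change. Placing (1-methyl-1H-imidazol-4-yl)sulfonyl there gives a 5.0-fold lower number from compound 1 to compound 3 (0.70 log units; beyond the scatter) and a 5.0-fold lower number from compound 2 to compound 3 (0.70 log units; beyond the scatter) in equal size, whether the group replaced carries 4-chlorophenyl or 1-methylethenyl. No measurement shown accounts for this difference.

This change alters both the sulfonyl link and the ring it carries, and the compounds shown cannot separate the two. From the compounds shown here alone, the outcome with (4-chlorophenyl)sulfonyl or (1-methyl-1H-imidazol-4-yl)carbonyl on this nitrogen remains open.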